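This account rests on a few compounds, and the source may have more. Where it says the series, first, only, none or still open, it means among the compounds named here.

Three members of the series share one core. Compound 1 `CC1(c2ccccc2)CC(=O)N(CC(=O)N2CCN(c3ccc(Cl)cc3)CC2)C1=O` is "not active" (no number reported) in a functional assay on the whole organism (strain CD-1) with Mus musculus as the target, in the maximal electroshock model, with a stated time of 2 h (on this read-out lower numbers stand for an effect already at smaller amounts and higher numbers for an effect only at larger amounts of compound), and no number is reported for it. Compound 2 `Cc1cccc(N2CCN(C(=O)CN3C(=O)CC(C)(c4ccccc4)C3=O)CC2)c1` gives 300 mg/kg in this assay. Compound 3 `CC1(c2ccccc2)CC(=O)N(CC(=O)N2CCN(c3ncccn3)CC2)C1=O` is "not active" (no number reported) in this assay, again without a number, so compound 3 stands with compound 1 among the entries that carry no single value, while compound 2 alone carries one. The next compound, compound 4 `CC1(c2ccccc2)CC(=O)N(CC(=O)N2CCN(c3cccc(Cl)c3Cl)CC2)C1=O`, differs from compound 3 in one place: 2,3-dichlorophenyl in place of pyrimidin-2-yl on an amine nitrogen in a ring. Among the measured compounds shown here, no step between measured compounds exists for this change, so the size of the step in this assay is open; a result at the level of compound 2 or again no activity are both plausible. For compound 4 the expected minimum effective dose is 300 mg/kg, in the range 100 mg/kg to 600 mg/kg.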

Compound 4, minimum effective dose: "not active" (no number reported)
For compound 4 the study gives words and no number; the estimate stays without a comparison.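

Compound 3 and compound 4 both stand in words without a number in this assay so no step can be read between them. The compounds shown leave open the size of the change from pyrimidin-2-yl to 2,3-dichlorophenyl. No supporting data bear on this result.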